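The compounds below may be only part of what the source reports. "The series", "measured", "known", "first", "only" and "open" are said of these compounds alone.

Working notes on the series. The common core carries a hydroxy, a methyl and two cinnamoyl-type arms; the variable part is the aryl group on the remaining position. Compound 1 `Cc1cc(O)c(C(=O)/C=C/c2ccc(F)cc2)c(-c2ccccc2)c1C(=O)/C=C/c1ccc(F)cc1` gives, in a functional assay on MCF7 cells (Homo sapiens) for cytotoxicity, read by MTT assay, with a stated time of 24 h (a higher number here means a weaker inhibitor, a lower number a stronger inhibitor), 20000 nM. Compound 2 `Cc1cc(O)c(C(=O)/C=C/c2ccc(F)cc2)c(-c2ccc(Br)cc2)c1C(=O)/C=C/c1ccc(F)cc1` gives in this assay 20000 nM, so compound 2 stands level with compound 1 on the numbers shown, the only numbered neighbour it has. Among the compounds with values here, the one measured step, no change at the digits printed from compound 1 to compound 2 (within the scatter), shows that bromo for hydrogen at this position moves nothing. Within the data shown here, compound 3 `Cc1cc(O)c(C(=O)/C=C/c2ccccc2)c(-c2ccc(OCc3ccccc3)cc2)c1C(=O)/C=C/c1ccccc1`, which carries the benzyloxy aryl group but unsubstituted cinnamoyl arms, is reported in this assay as "not active" (no number reported); no step to it is given, so it only says that the benzyloxy variant did not reach a number.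

Compound 4 `Cc1cc(O)c(C(=O)/C=C/c2ccc(F)cc2)c(-c2ccc(OCc3ccccc3)cc2)c1C(=O)/C=C/c1ccc(F)cc1` differs from compound 2 by benzyloxy in place of bromo on an aromatic carbon. Among the measured compounds shown here, the sole measured step at this position, from compound 1 to compound 2, was flat, and the benzyloxy analogue compound 3 gave no number. Nothing in the series therefore points to a step beyond the scatter in this assay, and the estimated step of no change at the digits printed from compound 2 to compound 4 (within the scatter) is expected to be essentially none. Compound 4 is accordingly expected to give about 20000 nM, with a range from 10000 nM to 40000 nM, and a real chance that only a limit is reported.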

Compound 4, half-maximal inhibitory concentration: 28000 nM
For compound 4 the middle estimate is 1.4-fold (0.15 log units) below the measured one; measured number inside the range.
By their numbers in this assay, from the lowest: compounds 1, 2 and 4 (each within the scatter of the next).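

At this position, the flat result no longer rests on a single bromine atom. In this assay, benzyloxy in place of bromo gives a 1.4-fold higher number from compound 2 to compound 4 (0.15 log units; within the scatter) and benzyloxy in place of hydrogen gives a 1.4-fold higher number from compound 1 to compound 4 (0.15 log units; within the scatter) even though the entering group has 8 heavy atoms, one six-membered aromatic ring of carbon only and 1 hydrogen-bond acceptor, so hydrogen, bromo and benzyloxy on the same core and arms do not separate compound 1, compound 2 and compound 4 beyond the scatter. No measurement is available that would explain this flat result.

The compounds shown leave open whether any group at this position can shift the number beyond the scatter, since only hydrogen, bromo and benzyloxy can be compared here, and an amine, a carboxylic acid or a longer alkoxy chain would test that with different atoms and a different reach. They also leave open whether the same flat picture would hold with other arms on the shared core, as no single-place comparison among them changes the arms.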